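The source may hold more compounds than are shown below. What is called first, only, known or untested is meant among the compounds shown, and "the series" means these compounds.

Measured in a functional assay on MCF7 cells (Homo sapiens) for cytotoxicity; a higher number here means that more compound is needed for the effect, a lower number that less compound is needed:
- compound 1 `COc1cc(/C=C/c2ccc(C(C)C)cc2)cc(OC)c1OC`: 18.4 uM
- compound 2 `COc1cc(/C=C\c2ccc(C(C)C)cc2)cc(OC)c1OC`: 1.4 uM

Compound 1 has the higher number of this pair, so more of it is needed for the effect. The next compound to test is compound 3 `COc1cc(/C=C/c2ccc(SC)cc2)cc(OC)c1OC`, which has methylsulfanyl in place of isopropyl on an aromatic carbon.

Going by the values given here, only one step has been measured, and it is large: a 13-fold lower number from compound 1 to compound 2 (1.12 log units; beyond the scatter). It is due to the fact that compounds 1 and 2 differ only in the configuration as drawn, with the double bond drawn E in compound 1 and Z in compound 2. That step leaves the isopropyl group untouched, so it gives no size for the swap made here. Compound 3 keeps the E double bond of compound 1, which gives 18.4 uM, so that value is the best starting point. No shift beyond the scatter is therefore expected in this assay, and the estimated step is a 1.2-fold lower number from compound 1 to compound 3 (0.09 log units; within the scatter). For compound 3 the expected value is 15 uM, with an estimated range from 5 uM to 45 uM.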

Compound 3, concentration for half-maximal effect: 5.9 uM
The estimate for compound 3 lay 2.5-fold (0.41 log units) above the measured number, and the stated range covers the measured number.
By their numbers in this assay, from the lowest: compound 2; then compound 3; then compound 1.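

In this assay, the group on this aromatic carbon matters in its own right: a 3.1-fold lower number from compound 1 to compound 3 (0.49 log units; beyond the scatter) comes with methylsulfanyl in place of isopropyl while the E double bond stays as it is. Going by these compounds alone, until now, the only measured change was the configuration of that double bond, so this is the first sign that the number also responds to the group itself. Methylsulfanyl has fewer heavy atoms than isopropyl and brings a sulfur and a hydrogen-bond acceptor, but nothing available shows which of these differences, if any, lies behind the shift.

Going by these compounds, whether methylsulfanyl would give a similar step on a Z double bond stays open, as the two changes are seen only separately. Also open, on these data alone, is how an amine, a carboxylic acid or a longer chain would behave on this carbon.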